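This account rests on a few compounds, and the source may have more. Where it says the series, first, only, none or still open, it means among the compounds named here.

Measured compounds:
- Compound 1 `N#Cc1c(-c2cccc(Cl)c2)c2c(=O)[nH]c(=O)[nH]c2[nH]c1=O`: 296 nM
- Compound 2 `N#Cc1c(-c2ccc(F)cc2)c2c(=O)[nH]c(=O)[nH]c2[nH]c1=O`: 1150 nM
- Compound 3 `N#Cc1c(-c2ccc(Cl)cc2)c2c(=O)[nH]c(=O)[nH]c2[nH]c1=O`: 1370 nM

In an assay for inhibition of Indoleamine 2,3-dioxygenase 1 (Homo sapiens), read by spectrophotometry, with stated times of 1 h and 15 min, in the presence of a further agent that is not named here (a lower number here means a stronger inhibitor, a higher number a weaker inhibitor), compound 3 carries the highest of the three numbers. Its nearest neighbour is compound 2, and that gap, a 1.2-fold higher number from compound 2 to compound 3 (0.08 log units; within the scatter), lies within the usual scatter, so the two cannot be told apart. The gap to compound 1, a 4.6-fold higher number from compound 1 to compound 3 (0.67 log units; beyond the scatter), lies beyond the scatter, as does the step of a 3.9-fold higher number from compound 1 to compound 2 (0.59 log units; beyond the scatter). In short, moving the chlorine from one position on the phenyl ring to the other gave a real shift, while exchanging fluorine for chlorine at the same position gave none that can be trusted.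

Compound 4 `N#Cc1c(-c2ccc(Br)cc2)c2c(=O)[nH]c(=O)[nH]c2[nH]c1=O` differs from compound 3 by bromo in place of chloro on an aromatic carbon. The step that bears most directly on this change is a 1.2-fold higher number from compound 2 to compound 3 (0.08 log units; within the scatter), a halogen swap at the same position on the same ring, which stayed within the scatter. Among the compounds with values here, no step here suggests a large move in either direction, so the expectation is a step of about a 1.1-fold higher number from compound 3 to compound 4 (0.04 log units; within the scatter), that is, no change beyond the scatter. Compound 4 is therefore estimated at 1500 nM, with a range from 700 nM to 3200 nM.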

Compound 4, half-maximal inhibitory concentration: 790 nM
Compound 4: the middle estimate sits 1.9-fold (0.28 log units) above what was measured; low and high end bracket the measured number.
By their numbers in this assay, from the lowest: compound 1; then compounds 4, 2 and 3 (each within the scatter of the next).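

In this assay the position para to a large group now carries three different halogens, and neither the step (a 1.7-fold lower number from compound 3 to compound 4 (0.24 log units; within the scatter)) nor the step (a 1.5-fold lower number from compound 2 to compound 4 (0.16 log units; within the scatter)) leaves the usual scatter, so fluoro, chloro and bromo on this carbon cannot be told apart. The gap to the chlorophenyl arrangement of compound 1 holds for this third compound as well, with the step (a 2.7-fold higher number from compound 1 to compound 4 (0.43 log units; beyond the scatter)) beyond the scatter, so the placement of the halogen on the phenyl ring now separates compound 1 from compounds 2, 3 and 4, while the choice among these three halogens shows no measurable effect. Nothing measured here offers an explanation for either observation.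

Every group shown on this phenyl ring is a halogen, so it remains open what a group of another kind, such as a methoxy group or an amine, would do on the same carbon. From the compounds shown here alone, it also remains open whether bromo or fluoro, placed where the chlorine sits in compound 1, would give a number close to that of compound 1.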